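The compounds below may be only part of what the source reports. "The series", "measured", "known", "first", "only" and "open" are said of these compounds alone.

Of the compounds shown here, three sharing one core have been measured in an assay on MDA-MB-231 cells for binding affinity to C-X-C chemokine receptor type 4 (Homo sapiens), read by fluorescence and microscopy, with stated times of 10 min and 30 min; a higher number here means that more compound is needed for the effect, a lower number that less compound is needed. Compound 1 `CCN(CC)Cc1ccc(S(=O)(=O)NCc2ccc(CNC(=O)c3ccc(F)cc3)cc2)cc1` gives 1 nM, and compound 2 `O=C(NCc1ccc(CNS(=O)(=O)c2ccc(CN3CCCC3)cc2)cc1)c1ccc(F)cc1` gives 1 nM; the step of no change at the digits printed from compound 1 to compound 2 (within the scatter). Compound 3 `Cc1ccccc1S(=O)(=O)NCc1ccc(CNC(=O)c2ccc(F)cc2)cc1` gives 100 nM, the highest of the three numbers, with its gap to compound 1 and to compound 2 beyond the scatter. Compound 4 `O=C(NCc1ccc(CNS(=O)(=O)c2cccc3ccccc23)cc1)c1ccc(F)cc1` has not been measured; it differs from compound 3 by naphthalen-1-yl in place of 2-methylphenyl on a sulfonyl sulfur. Going by the values given here, no measured step alters the group on the sulfonyl sulfur, so the only guide is that compound 3, carrying 2-methylphenyl there, sits far above compounds 1 and 2. The step of a 1.7-fold lower number from compound 3 to compound 4 (0.22 log units; within the scatter) is therefore an estimate with wide uncertainty, leaning toward a lower number. Compound 4 is expected to give about 60 nM, between 10 nM and 300 nM.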

Compound 4, effective concentration (reported as EC, without a stated level of effect): 1000 nM
For compound 4 the middle estimate is 17-fold (1.22 log units) below the measured one; measured number above the stated range.
By their numbers in this assay, from the lowest: compounds 1 and 2 (each within the scatter of the next); then compound 3; then compound 4.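

At the sulfonyl sulfur, naphthalen-1-yl in place of 2-methylphenyl brings a 10-fold higher number from compound 3 to compound 4 (1.00 log units; beyond the scatter) in this assay and so shows that this group alone can clearly shift the number. Here, a second six-membered aromatic ring goes with more compound being needed, not less. No measurement on hand accounts for this step. Going by these compounds, whether a primary amine or a carboxylic acid on the group at the sulfonyl sulfur would lower or raise the number remains open, and so does the effect of a longer chain there.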